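A few compounds are considered here, and "the series" means these few. Any claim that something is new, unique, unknown or untested is made for them only; others in the source may bear on it.

Measured so far in a functional assay on HEK293 cells for activation of 5-hydroxytryptamine receptor 4 (Homo sapiens), read by cAMP accumulation; on this read-out lower numbers stand for smaller maximal responses and higher numbers for larger maximal responses:
compound 1 `COc1cc(N)c(Cl)cc1C(=O)NCC1CCNCC1` — 81%
compound 2 `CC(C)n1c(=O)n(C(=O)NC2CCNCC2)c2ccccc21` — > 100%, a limit of the assay
compound 3 `CCCCCN1CCC(NC(=O)c2cc(Cl)c(N)cc2OC)CC1` — > 100%, a limit of the assay

Compound 1 gives a numerical value in this assay. Compound 2 reports only a limit, not a number. Compound 3 likewise reports only a limit, not a number, and so stands at the limit of > 100% in this assay, at which 2 of the 3 values shown sit. Going by the values given here, no pair of measured compounds differs in a single place, so no measured step exists for the change in hand. Compound 4 `COc1cc(N)c(Cl)cc1C(=O)NC1CCN(CCN2CCCCC2)CC1` differs from compound 3 in one place: piperidin-1-yl in place of propyl on a saturated chain carbon, two bonds along the chain from an amine nitrogen in a ring. With compound 3 already at the limit, no shift beyond the scatter is expected for this change in this assay. Compound 4 is expected at 100%, within 85% to 115%. The step this estimate means, a number no higher from compound 3 to compound 4 (the limit leaves the size open), is expected to stay within the scatter.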

Compound 4, intrinsic activity: the largest response reached, in percent of the reference agonist's: > 100%
Compound 4 ended at the assay's limit; the forecaster's own chance of this, stated with the estimate: 55%; the middle value lies on the limit itself.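

The step from compound 3 to compound 4 cannot be read, since both values are limits and not numbers: the limit of > 100% in this assay, at which 3 of the 4 values shown sit.

The compounds shown leave open how far piperidin-1-yl in place of propyl changes the maximal response.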